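Changing the aryl group on the amide carbonyl

This account rests on a few compounds, and the source may have more. Where it says the series, first, only, none or still open, it means among the compounds named here.

Measured compounds:
- compound 1 `COC(=O)c1cccc(C(=O)N2CCC(N(C3CC3)S(=O)(=O)c3cccc(C(F)(F)F)c3)CC2)c1`: "not determined" (no result reported)
- compound 2 `NC(=O)c1ccccc1C(=O)N1CCC(N(C2CC2)S(=O)(=O)c2cccc(C(F)(F)F)c2)CC1`: 11%

Among the measured compounds shown here, compound 2 holds the only number in this set. In an assay on cells for inhibition of Voltage-dependent L-type calcium channel subunit alpha-1C (Homo sapiens), read by FLIPR and calcium flux, tested at 1 uM (a higher number here means a stronger effect of the compound at the concentration tested, a lower number a weaker effect), compound 2 gives 11%, a weak effect at the concentration tested. In this assay compound 1 has "not determined" (no result reported), so nothing can be said of it beyond its structure.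

Compound 3 `CS(=O)(=O)c1ccc(F)cc1C(=O)N1CCC(N(C2CC2)S(=O)(=O)c2cccc(C(F)(F)F)c2)CC1` is the next compound to be measured. It differs from compound 2 in a single place: 5-fluoro-2-(methylsulfonyl)phenyl in place of 2-carbamoylphenyl on a carbonyl carbon. For the measured compounds named here, no step between two measured compounds is available here, so there is no earlier example of what such a swap does.

The expectation is therefore a step from compound 2 to compound 3 of a number 1 percentage points higher from compound 2 to compound 3 (within the scatter), none beyond the usual scatter, because compound 2 gives only 11% and there is no indication pointing either way. Compound 3 is estimated at 12%, expected to fall between 0% and 35%.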

Compound 3, a percentage reported as inhibition, at one concentration (the size of the read-out at that concentration, not a potency): 18%
Estimate against measurement, compound 3: 6 percentage points below; the range from low to high includes it.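

In this assay, putting 5-fluoro-2-(methylsulfonyl)phenyl in place of 2-carbamoylphenyl on the carbonyl carbon gives a number 7 percentage points higher from compound 2 to compound 3 (within the scatter). Among the compounds shown here, this is the first sign of how this position responds: the aryl group can be exchanged for one with more heavy atoms and no hydrogen-bond donor, and the read-out does not shift beyond normal variation. Nothing available here explains this result.

The compounds shown leave open whether any group on this carbonyl carbon can raise the effect beyond the scatter, for example a phenyl ring bearing an amine or a carboxylic acid, or a saturated ring such as cyclohexyl. They also leave open which part of the new group, the fluorine or the methylsulfonyl, matters on its own, since the two enter together.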